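The source may report more compounds than this note shows. Statements on the series, on what has been measured and on what is new or still open speak of the compounds shown alone.

For the measured compounds named here, compound 1 `O=C(c1ccc(-c2ccc3ncc(-c4ccc5cnccc5c4)n3c2)cc1)N1CCC(N2CCCCC2)CC1` is the stronger of the two compounds measured so far. In an assay on Sf21 cells for inhibition of MAP kinase-interacting serine/threonine-protein kinase 1 (Homo sapiens), read by luminescence and ADP-Glo, with stated times of 10 min and 40 min (a higher number here means a weaker inhibitor, a lower number a stronger inhibitor), compound 1 gives 2.4 nM. The other measured compound, compound 2 `O=C(c1ccc(-c2ccc3ncc(-c4cnc5ccccc5c4)n3c2)cc1)N1CCNCC1`, gives 67.6 nM in this assay; its number is higher than that of compound 1, and the gap lies beyond the usual scatter, but the two structures differ in more than one place, so no single change can be tied to that gap. Compound 3 `N[C@@H]1CCCN(C(=O)c2ccc(-c3ccc4ncc(-c5ccc6cnccc6c5)n4c3)cc2)C1` has not yet been tested. It differs from compound 1 in one place: 3-aminopiperidin-1-yl in place of 4-(piperidin-1-yl)piperidin-1-yl on a carbonyl carbon. Going by the values given here, no measured pair isolates such a change, so any expectation rests only on what the two measured compounds show. A modest loss is expected, the expected step being a 3.3-fold higher number from compound 1 to compound 3 (0.52 log units; beyond the scatter). Compound 3 is accordingly expected to give about 8 nM in this assay, most likely between 2 nM and 30 nM.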

Compound 3, half-maximal inhibitory concentration: 7.7 nM
Compound 3: middle estimate off by 1.0-fold (0.02 log units), on the high side; the measured number falls inside the stated range.
By their numbers in this assay, from the lowest: compound 1; then compound 3; then compound 2.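

For the compounds shown here, compound 3 gives the first single-place reading at this position: in this assay, exchanging 4-(piperidin-1-yl)piperidin-1-yl for 3-aminopiperidin-1-yl on a carbonyl carbon produces a 3.2-fold higher number from compound 1 to compound 3 (0.51 log units; beyond the scatter), a modest loss. Compound 3 still gives 7.7 nM, so the second six-membered ring of the group that leaves is not needed for single-digit nanomolar inhibition with this core. The change alters size, hydrogen-bond donors and stereochemistry at once, and nothing measured here explains the loss or assigns it to any one of these.

On these data alone, whether the ring amine of compound 3 matters remains open, and a plain piperidin-1-yl group at the same place would test that. Also open, as far as these compounds go, is how the opposite enantiomer of the 3-aminopiperidin-1-yl group or a 4-aminopiperidin-1-yl group would read.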